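Adding Bromo to the Phenyl Ring of Compound 2

The source may hold more compounds than are shown below. What is called first, only, known or untested is meant among the compounds shown, and "the series" means these compounds.

Measured so far in a physicochemical assay for solubility; a lower number here means a less soluble compound, a higher number a more soluble compound:
- compound 1 `COc1cc(OC)c(/C=C/S(=O)(=O)Nc2ccc(OC)c(NC(C)(C)C(=O)O)c2)c(OC)c1` gives 10000 ug/mL
- compound 2 `COc1cc(OC)c(/C=C/S(=O)(=O)Nc2ccc(OC)c(NC(C(=O)O)c3ccccc3)c2)c(OC)c1` gives 10000 ug/mL

Within the data shown here, compound 2 stands at 10000 ug/mL, level with the only other measured compound at the digits given. Among the measured compounds shown here, the single measured step shows no change at the digits printed from compound 1 to compound 2 (within the scatter), with carboxy(phenyl)methyl in place of 1-carboxy-1-methylethyl on a nitrogen on an aromatic ring.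

The next compound is compound 3 `COc1cc(OC)c(/C=C/S(=O)(=O)Nc2ccc(OC)c(NC(C(=O)O)c3ccc(Br)cc3)c2)c(OC)c1`, and the change is bromo in place of hydrogen on an aromatic carbon. This places bromo in place of hydrogen on an aromatic carbon, para to a large group, turning phenyl into 4-bromophenyl. For the measured compounds named here, the measured step bears on this only loosely: it concerns the same group on the nitrogen, but no measured compound carries bromo, so the evidence for this exact change is missing. Going by the values given here, with only that one flat step to go on, the expected result is no change at the digits printed from compound 2 to compound 3 (within the scatter) in this assay, with no move beyond the scatter in either direction. The estimate for compound 3 is 10000 ug/mL, with an expected range from 3000 ug/mL to 11000 ug/mL.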

Compound 3, solubility: 10000 ug/mL
The estimate for compound 3 equals the measured number at the digits printed, within the range that was stated.
By their numbers in this assay, from the lowest: compounds 1, 2 and 3 (each within the scatter of the next).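

In this assay, among these compounds, bromo in place of hydrogen on an aromatic carbon, para to a large group, gives no change at the digits printed from compound 2 to compound 3 (within the scatter); this is the first reading of a substituent on this phenyl ring, and turning phenyl into 4-bromophenyl leaves the printed value unmoved. The wider comparison on the same nitrogen, (4-bromophenyl)(carboxy)methyl in place of 1-carboxy-1-methylethyl, gives no change at the digits printed from compound 1 to compound 3 (within the scatter), so the level reading seen earlier for the unsubstituted phenyl group also holds with bromo on that ring, with compound 3 at 10000 ug/mL. No available evidence accounts for this result.

The compounds shown leave open whether a different group on the same aromatic carbon, such as an amine, a nitrile or a longer chain, would also stay level in this assay. They also leave open whether this reading would hold if an ester or an amide took the place of the carboxylic acid, since all three compounds carry that acid on the group attached to the nitrogen.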